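Trimming a methyl from the carbamate of compound 3

The source may hold more compounds than are shown below. What is called first, only, known or untested is meant among the compounds shown, and "the series" means these compounds.

Compound 3 `CC(C)(C)OC(=O)NCCS(=O)(=O)NC(=O)c1ccc(Nc2nc(NC3(c4ccc(Cl)cc4)CC3)nc(OCC(F)(F)F)n2)cc1` stands highest of the three compounds measured in a physicochemical assay for permeability, using PAMPA, at pH 7.4 (a higher number here means that the compound crosses the layer faster, a lower number that the compound crosses the layer more slowly), where compound 3 gives 111 nm/s. Compound 1 `CC(C)NCCS(=O)(=O)NC(=O)c1ccc(Nc2nc(NC3(c4ccc(Cl)cc4)CC3)nc(OCC(F)(F)F)n2)cc1` gives 45 nm/s in this assay, and compound 2 `CC(C)(C)NC(=O)NCCS(=O)(=O)NC(=O)c1ccc(Nc2nc(NC3(c4ccc(Cl)cc4)CC3)nc(OCC(F)(F)F)n2)cc1` gives 49 nm/s; the steps of a 2.5-fold higher number from compound 1 to compound 3 (0.39 log units; beyond the scatter) and a 2.3-fold higher number from compound 2 to compound 3 (0.36 log units; beyond the scatter) set compound 3 modestly apart, while a 1.1-fold higher number from compound 1 to compound 2 (0.04 log units; within the scatter) lies within the scatter.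

Compound 4 `CC(C)OC(=O)NCCS(=O)(=O)NC(=O)c1ccc(Nc2nc(NC3(c4ccc(Cl)cc4)CC3)nc(OCC(F)(F)F)n2)cc1` differs from compound 3 by one change: hydrogen in place of methyl on a saturated chain carbon bound to an oxygen next to a carbonyl group and two saturated chain carbons. For the measured compounds named here, no measured pair shows this exact change; the steps that reach compound 3 replace the whole group on the amine nitrogen or swap tert-butoxy for (tert-butyl)amino, and both were modest in size. The loss of a single carbon is a smaller change than either, so compound 4 is expected to sit close to compound 3, with at most a small drop in this assay, as a 1.3-fold lower number from compound 3 to compound 4 (0.12 log units; within the scatter). Compound 4 is therefore estimated at 85 nm/s, within a range from 45 nm/s to 160 nm/s.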

Compound 4, apparent permeability: 71 nm/s
The estimate for compound 4 lay 1.2-fold (0.08 log units) above the measured number; the measured number falls inside the stated range.
By their numbers in this assay, from the lowest: compounds 1, 2, 4 and 3 (each within the scatter of the next, the first and the last beyond it).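

In this assay, for the compounds shown here, the change from tert-butoxy to isopropoxy gives a 1.6-fold lower number from compound 3 to compound 4 (0.19 log units; within the scatter) and so stays within the scatter: at this saturated chain carbon, the loss of one methyl leaves no step that can be told apart from repeat variation. Compound 4 also stays within the scatter of the two lower compounds, with a 1.4-fold higher number from compound 2 to compound 4 (0.16 log units; within the scatter) and a 1.6-fold higher number from compound 1 to compound 4 (0.20 log units; within the scatter) as its steps. The isopropoxycarbonyl group therefore does not stand clear of the isopropyl or (tert-butyl)carbamoyl groups, whereas the tert-butoxycarbonyl group of compound 3 does. No measurement shown gives a reason for these numbers.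

As far as these compounds go, whether further trimming to an ethoxy or methoxy group would keep the number in this range remains open. So does the effect of a cyclopropyl or longer alkyl chain on the same carbamate oxygen.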